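A few compounds are considered here, and "the series" means these few. Any claim that something is new, unique, unknown or untested is made for them only; others in the source may bear on it.

For the measured compounds named here, in a functional assay on HT-29 cells (Homo sapiens) for cytotoxicity, read by MTT assay, with a stated time of 72 h (on this read-out lower numbers stand for stronger inhibition and higher numbers for weaker inhibition), compound 3 (`CCOC(=O)c1sc2ccccc2c1Nc1cc(OC)c(OC)c(OC)c1`) gives 1610 nM as the highest of the three numbers so far. Compound 1 (`COC(=O)c1sc2c(C)cccc2c1Nc1cc(OC)c(OC)c(OC)c1`) is the nearest at 552 nM and stays lower beyond the scatter. Compound 2 (`COC(=O)c1sc2cc(OC)ccc2c1Nc1cc(OC)c(OC)c(OC)c1`) lies furthest away at 0.9 nM on the low side. Compound 4 (`CCOC(=O)c1sc2cccc(C)c2c1Nc1cc(OC)c(OC)c(OC)c1`) has methyl in place of hydrogen on an aromatic carbon of compound 3 (methyl in place of hydrogen on an aromatic carbon). Going by the values given here, no measured pair shows this change alone, so no shift beyond the scatter is expected in this assay. The expected change is small (a 1.2-fold lower number from compound 3 to compound 4 (0.09 log units; within the scatter)) and slightly downward. For compound 4 the estimated value is 1300 nM with an expected range (300 nM to 6000 nM) that stays wide.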

Compound 4, half-maximal inhibitory concentration: 3610 nM
Beside the measured number, compound 4's estimate is 2.8-fold (0.44 log units) below it; measured number inside the range.
By their numbers in this assay, from the lowest: compound 2; then compound 1; then compound 3; then compound 4.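

For the compounds shown here, this is the first single-place step: in this assay methyl in place of hydrogen on the aromatic carbon ortho to a fused ring gives a 2.2-fold higher number from compound 3 to compound 4 (0.35 log units; beyond the scatter) and so weakens inhibition modestly. The position therefore responds to this change, yet the added methyl does not abolish activity. No measured evidence accounts for the shift.

On these data alone, whether an amine or a fluorine on the same carbon would move the number in the same direction remains open. So does whether methyl here behaves alike with a carboxylic acid in place of the ethyl ester.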